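Sulfur to selenium on a nitrothiophene bis-acyl isothiourea

The source may report more compounds than this note shows. Statements on the series, on what has been measured and on what is new or still open speak of the compounds shown alone.

Measured so far:
compound 1 `CS/C(=N\C(=O)c1sccc1Cl)NC(=O)c1sccc1Cl` gives 35600 nM
compound 2 `CS/C(=N\C(=O)c1csc([N+](=O)[O-])c1)NC(=O)c1csc([N+](=O)[O-])c1` gives 51800 nM
compound 3 `C[Se]/C(=N\C(=O)c1ccno1)NC(=O)c1ccno1` gives 0.79 nM

In a functional assay on HT-29 cells (Homo sapiens) for cytotoxicity, read by MTT assay, with a stated time of 72 h (on this read-out higher numbers stand for weaker inhibition of growth and lower numbers for stronger inhibition of growth), compound 2 gives the highest of the three numbers; compound 1 lies within the scatter of it, while compound 3 lies far beyond the scatter in the lower direction. Compound 4 `C[Se]/C(=N\C(=O)c1csc([N+](=O)[O-])c1)NC(=O)c1csc([N+](=O)[O-])c1` differs from compound 2 in one place: a group of 2 heavy atoms (1 carbon, 1 selenium; no ring) in place of a group of 2 heavy atoms (1 carbon, 1 sulfur; no ring), on a carbon with a double bond to nitrogen. Among the measured compounds shown here, no pair of measured compounds shows this change alone, since compound 3 carries the entering group on a different acyl ring. A step toward a lower number is expected for compound 4, of uncertain size, as compound 3 gives 0.79 nM but cannot separate the ring from the group. Compound 4 is estimated at 300 nM, range 3 nM to 30000 nM, a step of a 170-fold lower number from compound 2 to compound 4 (2.24 log units; beyond the scatter) expected.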

Compound 4, concentration for 50% growth inhibition: 0.63 nM
Compound 4: middle estimate off by 480-fold (2.68 log units), on the high side, and the stated range ends above it.
By their numbers in this assay, from the lowest: compounds 4 and 3 (each within the scatter of the next); then compounds 1 and 2 (each within the scatter of the next).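

In this assay the methylsulfanyl group gives way to its selenium-bearing counterpart on a carbon with a double bond to nitrogen, with an 82000-fold lower number from compound 2 to compound 4 (4.91 log units; beyond the scatter) as the result. Among the compounds shown here, with the acyl rings held fixed, this isolates a large step for this single change, which the earlier compounds could not do. No available evidence explains the step. Going by these compounds, whether it carries over to the acyl groups of compound 1 or compound 3 remains open, as no matched sulfur and selenium pair exists for either. Also open, on these data alone, is how a longer chain, such as ethyl, on the selenium would behave.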